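A few compounds are considered here, and "the series" means these few. Any claim that something is new, unique, unknown or untested is made for them only; others in the source may bear on it.

Measured so far in a functional assay on G-361 cells (Homo sapiens) for antiproliferative activity, with a stated time of 72 h; on this read-out higher numbers stand for weaker inhibition and lower numbers for stronger inhibition:
Compound 1, `OC[C@H]1O[C@@H](n2cnc3c(NCc4cccc(Br)c4)ncnc32)[C@H](O)[C@@H]1O`, gives > 166000 nM, a limit of the assay.
Compound 2, `Cc1cccc(CNc2ncnc3c2ncn3[C@@H]2O[C@H](CO)[C@@H](O)[C@H]2O)c1`, gives > 166000 nM, likewise a limit.
Compound 3, `OC[C@H]1O[C@@H](n2cnc3c(NCc4ccc(Cl)cc4Cl)ncnc32)[C@H](O)[C@@H]1O`, gives 128000 nM.

Compound 2 stands at the limit of this assay, as does compound 1 (the limit of > 166000 nM in this assay, at which 2 of the 3 values shown sit); only compound 3 yields a number. The step that the two limits leave unreadable from compound 1 to compound 2 cannot be read from two limits. Toward compound 3, the steps of an at least 1.2-fold lower number from compound 1 to compound 3 (0.11 log units; that floor lies within the scatter) and an at least 1.2-fold lower number from compound 2 to compound 3 (0.11 log units; that floor lies within the scatter) are floors that lie within the scatter, so compound 2 and compound 3 cannot be separated on these numbers.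

Compound 4, `OC[C@H]1O[C@@H](n2cnc3c(NCc4ccc(F)cc4Cl)ncnc32)[C@H](O)[C@@H]1O`, is not yet measured. It differs from compound 2 by 2-chloro-4-fluorophenyl in place of 3-methylphenyl on a saturated chain carbon bound to a nitrogen on an aromatic ring. The closest measured step is an at least 1.2-fold lower number from compound 2 to compound 3 (0.11 log units; that floor lies within the scatter), where 2,4-dichlorophenyl replaces the same 3-methylphenyl on the same saturated chain carbon; it gave no movement beyond the scatter. Going by the values given here, no other measured step bears on a 2-chloro-4-fluorophenyl. The expected step is therefore an at least 1.1-fold lower number from compound 2 to compound 4 (0.04 log units; that floor lies within the scatter), none beyond the scatter, with a real chance that this assay again returns only a limit. Compound 4 is estimated at 150000 nM, within 60000 nM to 400000 nM.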

Compound 4, half-maximal inhibitory concentration: > 166000 nM
Compound 4: no number, only a limit; the forecaster's own chance of this, stated with the estimate: 55%; middle value at least 1.1-fold (0.04 log units) from the limit.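

In this assay compound 4 gives > 166000 nM as a limit of the assay and not a number. Fluoro in place of chloro on an aromatic carbon gives an at least 1.2-fold higher number from compound 3 to compound 4 (0.11 log units; that floor lies within the scatter) and so does not separate the two, while the steps to compound 4 from compound 1 and compound 2 cannot be read. With 2-chloro-4-fluorophenyl at this place, one more compound joins the others at the same limit: the limit of > 166000 nM in this assay, at which 3 of the 4 values shown sit.

Compound 3 remains the only compound with a number, so the compounds shown cannot tell whether these substituted phenyl groups differ from one another in this assay. Open, as far as these compounds go, is whether an amine or a carboxylic acid on the phenyl group, or a longer chain at the saturated chain carbon, would bring a value clear of the limit.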